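This account rests on a few compounds, and the source may have more. Where it says the series, first, only, none or still open, it means among the compounds named here.

In an ADME assay on BHK-21 cells (Mesocricetus auratus) for cytotoxicity, with a stated time of 3 days (on this read-out higher numbers stand for lower toxicity in this test and lower numbers for higher toxicity in this test), compound 1 `CC(Sc1nnc(-c2ccncc2)s1)C(=O)Nc1ccccc1` gives > 50000 nM, which is a limit of the assay rather than a number, so compound 1 sits at the top of what this assay reports (the limit of > 50000 nM in this assay, at which 1 of the 2 values shown sits). Compound 2 `O=C(CCSc1nnc(-c2ccncc2)s1)NCc1ccccc1` gives 18700 nM in this assay, a plain number well inside the measured window. Compound 3 `CC(Sc1nnc(-c2ccncc2)s1)C(=O)Nc1ccc(Cl)cc1Cl` has not yet been measured; it differs from compound 1 by 2,4-dichlorophenyl in place of phenyl on an amide-type nitrogen. Among the compounds with values here, no step between two measured compounds that differ in a single place is available, so the size of this change has to be guessed from the structures alone. The step from compound 1 to compound 3 in this assay is expected to be modest and downward, though a result that again reaches the limit would not surprise, as an at least 1.6-fold lower number from compound 1 to compound 3 (0.22 log units; that floor lies within the scatter) indicates. For compound 3 the estimate in this assay is 30000 nM, with a range from 10000 nM to 100000 nM.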

Compound 3, half-maximal cytotoxic concentration: > 50000 nM
Compound 3: only a limit was reported; the forecaster's own chance of this, stated with the estimate: 40%; middle value at least 1.6-fold (0.22 log units) from the limit.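

In this assay compound 3 gives > 50000 nM, which is a limit and not a number. Within the data shown here, no step from compound 1 to compound 3 can be read, as both stand at a limit: the limit of > 50000 nM in this assay, at which 2 of the 3 values shown sit. The compounds shown leave open whether 2,4-dichlorophenyl in place of phenyl changes this read-out at all.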